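Moving the bromine on a chalcone-triazole cytotoxicity series

The compounds below may be only part of what the source reports. "The series", "measured", "known", "first", "only" and "open" are said of these compounds alone.

Among the compounds with values here, compound 2 `COc1ccc(C(=O)/C=C/c2ccc(OCc3cn(Cc4ccccc4Br)nn3)cc2)cc1` is one of two compounds measured in a functional assay on HepG2 cells (Homo sapiens) for cytotoxicity, read by MTT assay, with a stated time of 48 h (a lower number here means a stronger inhibitor, a higher number a weaker inhibitor), where compound 2 gives 20000 nM and stands as the higher of the two numbers. Within the data shown here, compound 1 `COc1ccc(C(=O)/C=C/c2ccc(OCc3cn(Cc4ccccc4)nn3)cc2)cc1` is its nearest neighbour; in this assay compound 1 gives 9000 nM, and the step from a 2.2-fold higher number from compound 1 to compound 2 (0.35 log units; beyond the scatter) is the only change measured so far. Compound 3 `COc1ccc(C(=O)/C=C/c2ccc(OCc3cn(Cc4ccc(Br)cc4)nn3)cc2)cc1` is unmeasured and differs from compound 2 as follows: 4-bromophenyl in place of 2-bromophenyl on a saturated chain carbon bound to an aromatic nitrogen. Among the measured compounds shown here, no measured step bears directly on shifting a bromine within the ring; the step from compound 1 to compound 2 speaks only to adding one. The expectation is therefore a step in this assay of about a 1.3-fold lower number from compound 2 to compound 3 (0.10 log units; within the scatter), likely no farther than the usual scatter in either direction. Compound 3 is estimated at 16000 nM, with a range from 7000 nM to 40000 nM.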

Compound 3, half-maximal inhibitory concentration: 8000 nM
For compound 3 the middle estimate is 2.0-fold (0.30 log units) above the measured one; the measured number falls inside the stated range.
By their numbers in this assay, from the lowest: compounds 3 and 1 (each within the scatter of the next); then compound 2.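

In this assay, shifting the bromine gives a 2.5-fold lower number from compound 2 to compound 3 (0.40 log units; beyond the scatter), so where the bromine sits on this ring affects the number, which the earlier addition of a bromine could not show. Bromo in place of hydrogen at the other place gives a 1.1-fold lower number from compound 1 to compound 3 (0.05 log units; within the scatter), so the higher number of compound 2 goes with 2-bromophenyl and not with the presence of bromine alone. No supporting data explain why the two placements differ.

The compounds shown leave open whether this dependence on place is particular to bromine or would also appear with a chlorine, a methoxy group or an amine on the same ring. On these data alone, it also remains open how a carboxylic acid there, or a longer chain in place of the benzyl link, would change the number.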